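Naphthalen-2-yloxy in place of phenoxy on the aryl ether

This account rests on a few compounds, and the source may have more. Where it says the series, first, only, none or still open, it means among the compounds named here.

Compound 3 `O=c1c2ccccc2nc(-c2ccccc2)n1/N=C/c1ccc(Oc2ccccc2)cc1` is the reference point. In a physicochemical assay for lipophilicity, in phosphate buffer, measured as octanol-water partition (on this read-out lower numbers stand for lower lipophilicity and higher numbers for higher lipophilicity), compound 3 gives 6.13, the second highest of the three numbers measured; compound 2 `O=c1c2ccccc2nc(-c2ccccc2)n1/N=C/c1ccc(Oc2ccc(Br)cc2)cc1` gives 6.39 and sits nearest, while compound 1 `Cc1nc2ccccc2c(=O)n1/N=C/c1ccc(Oc2ccc3ccccc3c2)cc1` gives 5.22 and lies furthest off. Among the measured compounds shown here, the only single-place step measured, a number 0.26 log units lower from compound 2 to compound 3 (within the scatter), removes a bromo and stays within the scatter. For the measured compounds named here, compound 1 differs from compound 3 in two places at once, so its number shows only that a methyl-bearing core with the naphthyl ether comes out lower than the phenyl-bearing core with the phenyl ether.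

Compound 4 `O=c1c2ccccc2nc(-c2ccccc2)n1/N=C/c1ccc(Oc2ccc3ccccc3c2)cc1` is not yet measured. The change is naphthalen-2-yl in place of phenyl on an oxygen on an aromatic ring, adding a second fused six-membered carbon ring at the ether oxygen. Going by the values given here, no measured step covers this change; the one step available, a number 0.26 log units lower from compound 2 to compound 3 (within the scatter), removes a heavy substituent with little effect, whereas here four aromatic carbons enter. An upward step beyond the scatter is expected, estimated at a number 0.62 log units higher from compound 3 to compound 4 (beyond the scatter). Compound 4 is therefore expected to give 6.75 in this assay, with a plausible range from 6.25 to 7.35.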

Compound 4, partition coefficient: 6.53
Compound 4: the middle estimate sits 0.22 log units above what was measured; the range from low to high includes it.
By their numbers in this assay, from the lowest: compound 1; then compounds 3, 2 and 4 (each within the scatter of the next, the first and the last beyond it).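

In this assay the ether position now has a step of its own beyond the scatter: a number 0.40 log units higher from compound 3 to compound 4 (beyond the scatter) with naphthalen-2-yl in place of phenyl on the oxygen, whereas the earlier bromo step on that aryl group stayed within the scatter. On the same oxygen, the step of a number 0.14 log units higher from compound 2 to compound 4 (within the scatter) leaves naphthalen-2-yl and 4-bromophenyl indistinguishable on this read-out, while the step of a number 1.31 log units higher from compound 1 to compound 4 (beyond the scatter) gives phenyl in place of methyl on an aromatic carbon as a large change in one place, which the two-place comparison of compound 1 with compound 3 could not separate from the ether change. Nothing at hand accounts for either the size of these steps or their direction.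

Still open, going by these compounds, is whether the naphthalen-2-yl step keeps its size on the methyl-bearing core of compound 1, and whether the phenyl for methyl step keeps its size with phenoxy on that ring. Also open, on these data alone, is how the read-out responds to an amine or a carboxylic acid on the ether aryl group in place of these carbon-only rings.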